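The source may report more compounds than this note shows. Statements on the series, on what has been measured and on what is new or still open speak of the compounds shown alone.

Measured compounds:
Compound 1, `Nc1scc(-c2ccccc2F)c1C(=O)c1ccccc1`: 55%
Compound 2, `Nc1scc(-c2ccc(Cl)cc2)c1C(=O)c1ccccc1`: 46%
Compound 3, `Nc1scc(-c2ccccc2F)c1C(=O)c1ccc(Cl)cc1`: 70%

All three compounds share one core and were tested in a functional assay on CHO cells for agonist activity at adenosine receptor A1 (Homo sapiens), read by fluorescence and ERK phosphorylation, with stated times of 30 min and 1.5 h, tested at 3 uM; on this read-out higher numbers stand for a stronger effect at the one concentration tested and lower numbers for a weaker effect. In this assay compound 3 gives 70%, the highest of the three numbers. Compound 1 is its nearest neighbour, separated by the step of a number 15 percentage points higher from compound 1 to compound 3 (beyond the scatter), which came from a chloro in place of hydrogen on an aromatic carbon. Compound 2, with 46%, lies further away from compound 3.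

The next compound, compound 4, `Nc1scc(-c2ccc(F)cc2)c1C(=O)c1ccc(Cl)cc1`, has not yet been measured. It differs from compound 3 in one place: 4-fluorophenyl in place of 2-fluorophenyl on an aromatic carbon. Going by the values given here, one measured step bears on this change. It is a number 9 percentage points lower from compound 1 to compound 2 (within the scatter), where a 4-chlorophenyl stood in place of a 2-fluorophenyl on an aromatic carbon, a change of similar kind though with a different halogen. Since that step stayed within the scatter, no shift beyond the scatter is expected here either, with at most a slight drift downward. Compound 4 is therefore expected to give about 63%, within a range from 46% to 80%. This estimate means a step of a number 7 percentage points lower from compound 3 to compound 4 (within the scatter) that is expected to remain within the scatter.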

Compound 4, a percentage reported as activity, at one concentration (the size of the read-out at that concentration, not a potency): 62%
Compound 4: the middle estimate sits 1 percentage points above what was measured; the measured number falls inside the stated range.
By their numbers in this assay, from the lowest: compounds 2, 1, 4 and 3 (each within the scatter of the next, the first and the last beyond it).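

In this assay, the change from 2-fluorophenyl to 4-fluorophenyl gives a number 8 percentage points lower from compound 3 to compound 4 (within the scatter), so moving the fluorine around this ring, with the atom count and the attachment point on the shared core unchanged, does not separate the two compounds at the one concentration tested. The earlier swap at this position, a number 9 percentage points lower from compound 1 to compound 2 (within the scatter), altered both the halogen and its place on the ring, whereas this pair isolates the place alone, and with it the position has now taken two changes, on cores with and without the chloro, with neither step going beyond the scatter. No measurement here explains why the read-out stays so similar across this change.

A single-concentration read-out is not a potency, so full concentration-response curves could still tell compound 3 and compound 4 apart. From the compounds shown here alone, all the groups seen at this position are halogen-bearing phenyl rings, so it remains open whether the same holds for a very different group there, such as a carboxylic acid, an amine or a longer alkyl chain.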